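Aryloxy for alkyl on the core: acid dissociation

This account rests on a few compounds, and the source may have more. Where it says the series, first, only, none or still open, it means among the compounds named here.

Measured compounds:
- compound 1, `COc1ccc(Oc2ccc3c(NCCCNCc4cc(F)ccc4OC)ccnc3c2)cc1`, 9.28
- compound 2, `COc1cccc(Oc2ccc3c(NCCCNCc4cc(F)ccc4OC)ccnc3c2)c1`, 9.28
- compound 3, `CCC(CC)c1ccc2c(NCCCNCc3cc(F)ccc3OC)ccnc2c1`, 9.47

In a physicochemical assay for acid dissociation, compound 3 gives the highest of the three numbers, yet its separation from the other two is small: the step of a number 0.19 log units higher from compound 1 to compound 3 (within the scatter) and the step of a number 0.19 log units higher from compound 2 to compound 3 (within the scatter) are both within the scatter, so no ordering among the three can be claimed. Compound 4, `COc1ccc(F)cc1CNCCCNc1ccnc2cc(Oc3cccc(N(C)C)c3)ccc12`, has not yet been measured in this assay. It differs from compound 3 in one place: 3-(dimethylamino)phenoxy in place of pentan-3-yl on an aromatic carbon.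

The two steps that bear on this change are the ones running the other way, from an aryloxy group to pentan-3-yl, namely a number 0.19 log units higher from compound 1 to compound 3 (within the scatter) and a number 0.19 log units higher from compound 2 to compound 3 (within the scatter). Both were within the scatter. The step of no change at the digits printed from compound 1 to compound 2 (within the scatter) shows that moving a methoxy group around the attached ring also left the number unchanged. Compound 4 carries an aryloxy group of the same kind as compounds 1 and 2, so the return from pentan-3-yl to an aryloxy group is expected to give a step of a number 0.17 log units lower from compound 3 to compound 4 (within the scatter) that stays within the scatter, if anything slightly downward. The estimate for compound 4 is therefore 9.3, with a range from 9.05 to 9.55.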

Compound 4, acid dissociation constant: 9.28
For compound 4 the middle estimate is 0.02 log units above the measured one, within the range that was stated.
By their numbers in this assay, from the lowest: compounds 1, 2, 4 and 3 (each within the scatter of the next).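

In this assay, within the data shown here, the earlier compounds varied only where a methoxy group sat on the attached ring, whereas compound 4 carries a dimethylamino group on that ring, which brings in a new nitrogen, and the number still shows no change at the digits printed from compound 2 to compound 4 (within the scatter) and no change at the digits printed from compound 1 to compound 4 (within the scatter) as well. Replacing pentan-3-yl, which has no ring, with the larger 3-(dimethylamino)phenoxy gives a number 0.19 log units lower from compound 3 to compound 4 (within the scatter), so this change on the aromatic carbon of the shared core also stays inside the usual spread of repeat measurements. Across these four compounds, then, neither the alkyl group, the aryloxy groups nor the swap of methoxy for dimethylamino separates the readings, and no compound goes against that.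

Nothing shown explains why the readings stay so close together, and no measurement points to which part of these molecules the number reports. Still open, going by these compounds, is whether a carboxylic acid or a primary amine on the attached ring, or a single chlorine on the aromatic carbon in place of the whole aryloxy group, would leave the number just as close to those of compounds 1 to 4.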